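A few compounds are considered here, and "the series" means these few. Any claim that something is new, unique, unknown or untested is made for them only; others in the source may bear on it.

Working notes on the series. In a functional assay on A549 cells (Homo sapiens) for antiproliferative activity, read by sulforhodamine B assay, with a stated time of 72 h (a higher number here means a weaker inhibitor, a lower number a stronger inhibitor), compound 1 `CC(C)C[C@H](NC(=O)CSc1cc(NS(=O)(=O)c2ccc(Cl)cc2)c2ccccc2c1O)B(O)O` gives 6900 nM and compound 2 `CC(C)C[C@H](NC(=O)CSc1cc(NS(=O)(=O)c2cccs2)c2ccccc2c1O)B(O)O` gives 7540 nM. Among the measured compounds shown here, these two values lie within the scatter of each other, so compound 2 stands level with compound 1 on the numbers so far.

The next compound is compound 3 `CC(=O)Nc1ccc(S(=O)(=O)Nc2cc(SCC(=O)N[C@@H](CC(C)C)B(O)O)c(O)c3ccccc23)cc1`. It keeps the core of compound 2 and changes only the group on the sulfonyl sulfur: 4-acetamidophenyl in place of thiophen-2-yl on a sulfonyl sulfur. In words, this is 4-acetamidophenyl in place of thiophen-2-yl on a sulfonyl sulfur.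

For the measured compounds named here, one measured step bears on this, as it changes the group at the same place: a 1.1-fold higher number from compound 1 to compound 2 (0.04 log units; within the scatter). That step stays within the scatter. Going by the values given here, it is the only evidence, and no measured compound yet carries the 4-acetamidophenyl group, so the range must stay wide. In this assay, no shift beyond the scatter is expected, and neither direction is favoured. The expected step is a 1.1-fold higher number from compound 2 to compound 3 (0.03 log units; within the scatter). For compound 3, the estimated value is 8000 nM, with an expected range of 3000 nM to 20000 nM.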

Compound 3, half-maximal inhibitory concentration: 6700 nM
Beside the measured number, compound 3's estimate is 1.2-fold (0.08 log units) above it, and the stated range covers the measured number.
By their numbers in this assay, from the lowest: compounds 3, 1 and 2 (each within the scatter of the next).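

In this assay, the 4-acetamidophenyl group, with more heavy atoms than thiophen-2-yl and a hydrogen-bond donor that thiophen-2-yl lacks, gives a 1.1-fold lower number from compound 2 to compound 3 (0.05 log units; within the scatter), so this larger change on a sulfonyl sulfur also leaves the number within the scatter. Acetamido in place of chloro on an aromatic carbon gives a 1.0-fold lower number from compound 1 to compound 3 (0.01 log units; within the scatter), which shows that this exchange on the phenyl ring likewise produces no readable shift, and across compound 1, compound 2 and compound 3 none of the three groups on the sulfonyl sulfur stands apart from the others, with no compound among them going against this. The data shown offer no measurement that would account for this flat result.

From the compounds shown here alone, the three compounds cover only aromatic groups at this position, so it remains open whether a carboxylic acid or an amine on the phenyl ring, or a plain methyl in place of the ring on a sulfonyl sulfur, would move the number beyond the scatter. All three also share the rest of the core, so they say nothing about how a change elsewhere in the structure would read in this assay.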